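From 3-cyanophenyl to 3,3,3-trifluoropropyl on the Sulfonyl Sulfur

This account rests on a few compounds, and the source may have more. Where it says the series, first, only, none or still open, it means among the compounds named here.

In an assay (strain Sprague-Dawley) for inhibition of Amine oxidase [flavin-containing] B (Rattus norvegicus), read by spectrophotometry, with a stated time of 5 min, tested at 10 uM (on this read-out higher numbers stand for more inhibition at the one concentration tested (going by the name of the read-out) and lower numbers for less inhibition), the three measured compounds gave:
compound 1, `CNC(=O)/C=C1/COc2cc(OS(=O)(=O)c3cccc(C#N)c3)ccc21`: 0%
compound 2, `CNC(=O)/C=C1/COc2c1ccc(OS(=O)(=O)c1ccc(C#N)cc1)c2C`: 6%
compound 3, `CNC(=O)/C=C1/COc2c1ccc(OS(=O)(=O)c1ccc(OC)cc1)c2C`: 0%

All three numbers sit near the floor of the read-out. Compound 1 stands level with compound 3 at the digits shown, and the two of them are together the lowest of the three; compound 2 lies only a few points higher, within the scatter, so no order among the three can be claimed.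

Among the compounds with values here, the one single-point step that has been measured runs a number 6 percentage points lower from compound 2 to compound 3 (within the scatter), a change on the aromatic ring attached to the sulfonyl sulfur. Compound 4, `CNC(=O)/C=C1/COc2cc(OS(=O)(=O)CCC(F)(F)F)ccc21`, differs from compound 1 in a more far-reaching way: 3,3,3-trifluoropropyl in place of 3-cyanophenyl on a sulfonyl sulfur. Within the data shown here, no measured step exchanges the whole aromatic ring for a chain, so the step from compound 2 to compound 3 bears only loosely on it; what it does show is that altering the group on the sulfonyl sulfur left the read-out near zero.

Among the measured compounds shown here, with compound 1 already at the floor and no measured step pointing upward, no change beyond the scatter is expected, which is what a number 3 percentage points higher from compound 1 to compound 4 (within the scatter) states. Compound 4 is therefore estimated at 3%, with a range from -8% to 15%.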

Compound 4, a percentage reported as inhibition, at one concentration (the size of the read-out at that concentration, not a potency): 17%
Compound 4: middle estimate off by 14 percentage points, on the low side, and the stated range ends below it.
By their numbers in this assay, from the lowest: compounds 1, 3 and 2 (each within the scatter of the next); then compound 4.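

On the sulfonyl sulfur of the core of compound 1, the group in place does affect the read-out: in this assay, exchanging 3-cyanophenyl for 3,3,3-trifluoropropyl gives a number 17 percentage points higher from compound 1 to compound 4 (beyond the scatter) and so clears the usual scatter, which the earlier step between two aromatic groups did not. An open chain with no ring can therefore stand on this sulfur and lift the read-out off the floor, although this is a modest step in a percentage taken at one concentration, and it says nothing about potency. No measurement at hand explains the rise, and these data cannot separate the loss of the ring, the loss of the nitrile and the arrival of the fluorines.

The compounds shown leave open whether the fluorines matter or whether any chain would do, a question that a plain propyl group on the same sulfur would help to answer. They also leave open whether the read-out would keep rising with a longer chain, such as a hexyl group, or would respond to an amine carried on the chain.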